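The compounds below may be only part of what the source reports. "The series", "measured", "known", "first", "only" and "open" are said of these compounds alone.

Working notes on the series.

Compound 1 `Nc1sc2c(c1C(=O)c1ccc(Br)c3ccccc13)CCC2` carries bromo on the naphthalene-type two-ring part of the molecule; in an assay on isolated protein with adenosine receptor A3 (Homo sapiens) as the target, tested at 10 uM (on this read-out lower numbers stand for less inhibition and higher numbers for more inhibition at the one concentration tested (going by the name of the read-out)), compound 1 gives 22%. Compound 2 `Nc1sc2c(c1C(=O)c1ccc(I)c3ccccc13)CCC2` is its iodo counterpart, and in this assay compound 2 gives 0%. The change between them is iodo in place of bromo on an aromatic carbon; the step it made is a number 22 percentage points lower from compound 1 to compound 2 (beyond the scatter).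

Compound 3 `Nc1sc2c(c1C(=O)c1ccc(Br)c3ccccc13)CCCC2` has a different core; how the core of compound 3 differs from the core of compound 1 is not broken down here. In this assay, for the measured compounds named here, compound 3 gives 48.5%, the highest of the three numbers measured so far, beyond the scatter from both compound 1 and compound 2.

Compound 4 `Nc1sc2c(c1C(=O)c1ccc(I)c3ccccc13)CCCC2` has not yet been measured. It stands to compound 3 as compound 2 stands to compound 1: the change is iodo in place of bromo on an aromatic carbon, the same change as before, with the same surroundings. Because compound 1 to compound 2 gave a number 22 percentage points lower from compound 1 to compound 2 (beyond the scatter), a step of similar size is expected from compound 3 to compound 4 in this assay, namely a number 23.5 percentage points lower from compound 3 to compound 4 (beyond the scatter). The estimate for compound 4 is 25%, expected between 5% and 45%.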

Compound 4, a percentage reported as inhibition, at one concentration (the size of the read-out at that concentration, not a potency): 48%
Beside the measured number, compound 4's estimate is 23 percentage points below it; measured number above the stated range.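

In this assay, iodo in place of bromo on an aromatic carbon gave a number 0.5 percentage points lower from compound 3 to compound 4 (within the scatter), so the change did not carry over from the core of compound 1 to the core of compound 3 with the size it had on the first core: the same change on two cores in this assay, a number 22 percentage points lower (beyond the scatter) from compound 1 to compound 2 and a number 0.5 percentage points lower (within the scatter) from compound 3 to compound 4, 21.5 percentage points apart, beyond the scatter of two such steps

In this series, then, a step read for this exchange on one core is no safe guide to the step on the other, and the core has to be taken into account whenever the exchange is carried across. Two pairs give no general rule for further cores, however, and these readings at one concentration show neither what in the two cores separates the steps nor how potency compares.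

Still open, going by these compounds, is how other groups at the same place on the core of compound 3 would read, such as chloro, methoxy or an amine. Also open, on these data alone, is whether the bromo and iodo pair would behave on any core beyond these two as it does on either of them.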